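This account rests on a few compounds, and the source may have more. Where it says the series, first, only, none or still open, it means among the compounds named here.

In a functional assay on G-361 cells (Homo sapiens) for inhibition, with a stated time of 72 h (on this read-out higher numbers stand for weaker inhibition and lower numbers for stronger inhibition), the measured compounds stand as follows. Compound 1, `NC1CCC(Nc2nc(NCc3ccc(-c4ccsc4)cc3)c3ncn(C4CCCC4)c3n2)CC1`, gave 570 nM. Compound 2, `NC1CCC(Nc2nc(NCc3ccc(-c4ccsc4)nc3)c3ncn(C4CCCC4)c3n2)CC1`, gave 272 nM. Compound 3, `NC1CCC(Nc2nc(NCc3ccc(-c4ccccc4O)cc3)c3ncn(C4CCCC4)c3n2)CC1`, gave 4150 nM.

Compound 2 differs from compound 1 only in the core: 6-(thiophen-3-yl)pyridin-3-yl in place of 4-(thiophen-3-yl)phenyl on a saturated chain carbon bound to a nitrogen on an aromatic ring. In this assay this brought a 2.1-fold lower number from compound 1 to compound 2 (0.32 log units; beyond the scatter). Compound 3 keeps the core of compound 1 and differs from it by 2-hydroxyphenyl in place of thiophen-3-yl on an aromatic carbon, which brought a 7.3-fold higher number from compound 1 to compound 3 (0.86 log units; beyond the scatter).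

Compound 4, `NC1CCC(Nc2nc(NCc3ccc(-c4ccccc4O)nc3)c3ncn(C4CCCC4)c3n2)CC1`, is not yet measured. It differs from compound 2 by 2-hydroxyphenyl in place of thiophen-3-yl on an aromatic carbon. The place is not identical: in the step to compound 4 the aromatic carbon belongs to a six-membered aromatic ring with 1 nitrogen and lies next to the ring nitrogen, whereas from compound 1 to compound 3 it belongs to a six-membered aromatic ring of carbon only. The change is therefore the same kind of change, not the same.

For compound 4 in this assay a step of a 7.4-fold higher number from compound 2 to compound 4 (0.87 log units; beyond the scatter) is expected, resting on the step from compound 1 to compound 3, a 7.3-fold higher number from compound 1 to compound 3 (0.86 log units; beyond the scatter), applied to compound 2 at 272 nM. Compound 4 is thus estimated at 2000 nM, most likely between 700 nM and 6000 nM.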

Compound 4, half-maximal inhibitory concentration: 24 nM
For compound 4 the middle estimate is 83-fold (1.92 log units) above the measured one; the whole stated range lies above it.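

In this assay, putting 2-hydroxyphenyl in place of thiophen-3-yl on the core of compound 2 gave an 11-fold lower number from compound 2 to compound 4 (1.05 log units; beyond the scatter), so the change did not carry over from one core to the other and even reversed its direction: the same change on two cores in this assay, a 7.3-fold higher number (0.86 log units; beyond the scatter) from compound 1 to compound 3 and an 11-fold lower number (1.05 log units; beyond the scatter) from compound 2 to compound 4, 83-fold (1.92 log units) apart, beyond the scatter of two such steps A step read on one of these two cores therefore cannot be applied to the other, and the result of this change depends on whether the ring carrying it holds a nitrogen. This single pair of cores does not show why the two steps part, nor does it give a rule for other cores or other groups.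

On these data alone, whether the reversal belongs to the hydroxyl group remains open. A plain phenyl or a 2-methoxyphenyl on both cores would bear on that question.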